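Three Inactive Nucleosides and a Fourth Still to Test

A few compounds are considered here, and "the series" means these few. Any claim that something is new, unique, unknown or untested is made for them only; others in the source may bear on it.

Measured so far:
- compound 1, `CNc1ncnc2c1c(-c1ccccc1)cn2[C@@H]1O[C@H](CO)[C@@H](O)[C@H]1O`: in a functional assay on K562 cells (Homo sapiens), read by MTT assay, with a stated time of 72 h (on this read-out lower numbers stand for stronger inhibition and higher numbers for weaker inhibition), compound 1 gives > 20000 nM, which is a limit of the assay rather than a number.
- compound 2, `O=c1[nH]cnc2c1c(-c1cc3ccccc3o1)cn2[C@@H]1O[C@H](CO)[C@@H](O)[C@H]1O`: in this assay compound 2 gives > 20000 nM, again a limit.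
- compound 3, `CNc1ncnc2c1c(-c1cc3ccccc3o1)cn2[C@@H]1O[C@H](CO)[C@@H](O)[C@H]1O`: in this assay compound 3 gives > 20000 nM, also a limit.

Compound 3 and compound 1 differ in one place, (phenyl in place of 1-benzofuran-2-yl on an aromatic carbon). The step that the two limits leave unreadable from compound 3 to compound 1 cannot be sized, since both values are limits. Compound 2 carries the same core as compound 3 except at one spot, but the difference between the two cores is not broken down here.

Compound 4, `O=c1[nH]cnc2c1c(-c1ccccc1)cn2[C@@H]1O[C@H](CO)[C@@H](O)[C@H]1O`, has not yet been measured. It stands to compound 2 exactly as compound 1 stands to compound 3: the change is phenyl in place of 1-benzofuran-2-yl on an aromatic carbon, and the surroundings of the place are described in the same words, so it is the same change. Going by the values given here, the only measured instance of it left both partners at the limit, and every value shown sits at that limit because of the limit of > 20000 nM in this assay, at which 3 of the 3 values shown sit. For compound 2 to compound 4 a step that the limit leaves unreadable from compound 2 to compound 4 is therefore expected, meaning no readable movement. Compound 4 is estimated to give roughly 30000 nM in this assay, most likely reported again as a limit, with a plausible range from 10000 nM to 100000 nM.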

Compound 4, half-maximal inhibitory concentration: > 20000 nM
Compound 4: only a limit was reported; the forecaster's own chance of this, stated with the estimate: 85%; the middle value is on the limit's open side.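

In this assay compound 4 gives > 20000 nM, which is a limit and not a number. Compound 2 also stands at a limit, so no size can be read for the step from compound 2 to compound 4: the limit of > 20000 nM in this assay, at which 4 of the 4 values shown sit.

The compounds shown leave open how phenyl and 1-benzofuran-2-yl compare once a value in this assay can be read as a number.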